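The source may hold more compounds than are shown below. What is called first, only, known or untested is meant among the compounds shown, and "the series" means these compounds.

Of the compounds shown here, two built on a shared core have been measured in a functional assay on MDA-MB-231 cells (Homo sapiens) for cytotoxicity, read by sulforhodamine B assay, with a stated time of 48 h; on this read-out lower numbers stand for stronger inhibition of growth and higher numbers for weaker inhibition of growth. Compound 1 `ClCc1ccc(Cn2cnc3c(Cl)ncnc32)cc1` gives 1770 nM. Compound 2 `ClCc1ccccc1Cn1cnc2c(Cl)nc(Cl)nc21`, which carries two chloro groups on its core, gives 330 nM, the lower of the two numbers and beyond the scatter from compound 1. The next compound, compound 3 `ClCc1ccccc1Cn1cnc2c(Cl)ncnc21`, differs from compound 2 in one place: hydrogen in place of chloro on an aromatic carbon. Among the compounds with values here, no measured pair shows this change on its own, so its effect has to be estimated. Compound 1 gives 1770 nM with a single chloro on its core, and on that basis the loss of a chloro is expected to weaken growth inhibition somewhat, though compound 1 differs from compound 2 in a second place as well. The step of a 2.4-fold higher number from compound 2 to compound 3 (0.38 log units; beyond the scatter) is expected to be modest, toward a higher number. Compound 3 is therefore estimated at 800 nM, within 300 nM to 2500 nM.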

Compound 3, concentration for 50% growth inhibition: 3020 nM
Compound 3: the middle estimate sits 3.8-fold (0.58 log units) below what was measured, and the stated range ends below it.
By their numbers in this assay, from the lowest: compound 2; then compounds 1 and 3 (each within the scatter of the next).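

In this assay, the chloro group on the aromatic carbon between two ring nitrogen atoms clearly counts: putting hydrogen in its place gives a 9.2-fold higher number from compound 2 to compound 3 (0.96 log units; beyond the scatter) for this single change. Compound 2 and compound 3 are the first pair shown to differ in this one place alone, so the effect of this chloro group can now be read directly rather than inferred from compounds that also differ elsewhere. Nothing available here shows why removing this chloro group weakens growth inhibition.

Going by these compounds, whether an amine, a methoxy group or a fluoro group on this same carbon would match the chloro group remains open. Also open, on these data alone, is whether this chloro group would make a difference of similar size with the chloromethyl group placed as in compound 1.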